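Bromo for Methyl on a Chalcone Scaffold

The source may report more compounds than this note shows. Statements on the series, on what has been measured and on what is new or still open speak of the compounds shown alone.

Compound 1 `Cc1cccc(/C=C/C(=O)c2ccccc2O)c1` has the highest of the two numbers recorded so far in a functional assay on HCT-116 cells (Homo sapiens) for cytotoxicity, read by MTT assay, with a stated time of 48 h, tested at 15 uM; on this read-out lower numbers stand for a stronger effect and higher numbers for a weaker effect at the one concentration tested. In this assay compound 1 gives 85.9%, while compound 2 `O=C(/C=C/c1ccc(Br)cc1)c1ccccc1O`, which also carries a bromo group, gives 68.4%, a gap that lies beyond the usual scatter. Compound 3 `O=C(/C=C/c1cccc(Br)c1)c1ccccc1O` has not yet been measured. It differs from compound 1 by bromo in place of methyl on an aromatic carbon. In this assay a modest downward step is expected, a number 10.9 percentage points lower from compound 1 to compound 3 (beyond the scatter), only about the size of the scatter, because compound 2 with its bromo group gives 68.4%. Compound 3 is therefore estimated at 75%, within a range of 60% to 90%.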

Compound 3, a percentage reported as activity, at one concentration (the size of the read-out at that concentration, not a potency): 29.6%
Estimate against measurement, compound 3: 45.4 percentage points above; measured number outside the range, below it.
By their numbers in this assay, from the lowest: compound 3; then compound 2; then compound 1.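

In this assay bromo in place of methyl on an aromatic carbon, meta to a large group, brings a number 56.3 percentage points lower from compound 1 to compound 3 (beyond the scatter) and so shows that this one place responds strongly to the exchange of a single heavy atom. The earlier pair could not show this, since compound 1 and compound 2 differ in more than one place. Nothing measured on these compounds bears on why the step is so large.

Going by these compounds, how chloro, an amine or a carboxylic acid at this place would compare with bromo stays open, as does whether the same exchange would give a similar step on another core.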